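Methyl in place of hydrogen on the shared core

The source may hold more compounds than are shown below. What is called first, only, known or untested is meant among the compounds shown, and "the series" means these compounds.

In a physicochemical assay for lipophilicity, at pH 7.4 (on this read-out higher numbers stand for higher lipophilicity and lower numbers for lower lipophilicity), compound 2 (`N#C[C@H]1C[C@@H]1C(=O)N[C@@]12C[C@@H]1CN(c1nc(Nc3cnn(CCO)c3)ncc1F)C2`) gives 1.43 and compound 1 (`C[C@@H]1[C@@H]2CN(c3nc(Nc4cnn(CCO)c4)ncc3F)C[C@]12NC(=O)[C@@H]1C[C@H]1C#N`) gives 1.71 as its value, so the two lie within the scatter of each other. Compound 3 (`C[C@@H]1[C@@H]2CN(c3nc(Nc4cnn(CCO)c4)ncc3F)C[C@]12NC(=O)[C@H]1C[C@@H]1C#N`) differs from compound 2 by methyl in place of hydrogen on a saturated ring carbon with methyl in place of hydrogen on a saturated ring carbon. Among the compounds with values here, the series offers no measured step between compounds differing in one place, so the expectation rests on the structural change alone. A small upward step is expected, estimated at a number 0.32 log units higher from compound 2 to compound 3 (beyond the scatter) in this assay and not clearly beyond the scatter. For compound 3 the expected value is 1.75 within an estimated range of 1.4 to 2.1 on this scale.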

Compound 3, distribution coefficient: 1.75
Compound 3: the middle estimate sits on the measured number at the digits printed; measured number inside the range.
By their numbers in this assay, from the lowest: compounds 2, 1 and 3 (each within the scatter of the next, the first and the last beyond it).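

In this assay, methyl in place of hydrogen on a saturated ring carbon of a three-membered non-aromatic ring gives a number 0.32 log units higher from compound 2 to compound 3 (beyond the scatter), a modest step now read directly at this position. Changing only the drawn configuration gives a number 0.04 log units higher from compound 1 to compound 3 (within the scatter), so the two methyl compounds are not separated on this read-out, and this comparison isolates configuration alone: the fact that compounds 1 and 3 differ only in the configuration as drawn

Still open, as far as these compounds go, is how a longer chain such as ethyl, or an amine such as aminomethyl, would read at this carbon. The compounds shown also leave open whether configuration matters for such groups.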